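This account rests on a few compounds, and the source may have more. Where it says the series, first, only, none or still open, it means among the compounds named here.

Series notes. Among the compounds with values here, compound 2 `O=S(=O)(NCCCNCc1cccc2ccccc12)c1cc(C(F)(F)F)cc(C(F)(F)F)c1` carries naphthalen-1-yl on a saturated chain carbon bound to an amine nitrogen; in a functional assay on A2780 cells (Homo sapiens) for inhibition, read by MTT assay, with a stated time of 72 h (a higher number here means a weaker inhibitor of growth, a lower number a stronger inhibitor of growth), compound 2 gives 3100 nM, the higher of the two numbers measured so far. The nearest neighbour is compound 1 `O=S(=O)(NCCCNCc1ccc(C(F)(F)F)cc1)c1cc(C(F)(F)F)cc(C(F)(F)F)c1`, which in this assay gives 2800 nM; the step of a 1.1-fold higher number from compound 1 to compound 2 (0.04 log units; within the scatter) lies within the scatter, so the two numbers are not distinguished.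

Compound 3 `O=S(=O)(NCCCNCc1ccc(Cl)cc1)c1cc(C(F)(F)F)cc(C(F)(F)F)c1` differs from compound 2 by 4-chlorophenyl in place of naphthalen-1-yl on a saturated chain carbon bound to an amine nitrogen. Within the data shown here, the only measured step bearing on this position, a 1.1-fold higher number from compound 1 to compound 2 (0.04 log units; within the scatter), exchanged one aryl for another at the same place and left the number essentially unchanged. A further aryl exchange there is therefore expected to produce no step beyond the scatter in this assay. For compound 3 the expected step is a 1.1-fold lower number from compound 2 to compound 3 (0.03 log units; within the scatter). Compound 3 is estimated at 2900 nM, with a range of 1400 nM to 6000 nM.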

Compound 3, concentration for 50% growth inhibition: 1800 nM
Compound 3: middle estimate off by 1.6-fold (0.21 log units), on the high side; measured number inside the range.
By their numbers in this assay, from the lowest: compounds 3, 1 and 2 (each within the scatter of the next).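

In this assay the new steps, a 1.7-fold lower number from compound 2 to compound 3 (0.24 log units; within the scatter) and a 1.6-fold lower number from compound 1 to compound 3 (0.19 log units; within the scatter), both stay within the scatter, so compound 1, compound 2 and compound 3 are not distinguished. The second step adds something the earlier pair did not show: chloro in place of trifluoromethyl on an aromatic carbon, a change of one substituent with the aryl group otherwise kept, leaves the number as undistinguished as the exchange of 4-chlorophenyl for naphthalen-1-yl does. Nothing available explains why these exchanges stay within the scatter.

Still open, from the compounds shown here alone, is whether a saturated cyclohexyl group in place of the aryl group, or a carboxylic acid or an amine on it, would give a step beyond the scatter. A longer chain in the shared core is equally untested by the compounds shown.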